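A few compounds are considered here, and "the series" means these few. Any claim that something is new, unique, unknown or untested is made for them only; others in the source may bear on it.

Working notes on the series. Compound 1, of structure `CCCCC[Se]c1nc([Se]CCCCC)c2cccnc2n1`, is read in an ADME assay on BEAS-2B cells (Homo sapiens) for cytotoxicity, read by MTT assay, with a stated time of 72 h; a lower number here means a stronger inhibitor of growth, a higher number a weaker inhibitor of growth. For compound 1 the result is only the limit of > 100000 nM, not a number. Compound 3, of structure `CSc1nc(NCc2ccc([Se]C)cc2)c2ccccc2n1`, likewise reaches only the limit of > 100000 nM in this assay. Compound 2, of structure `CSc1ccc(CNc2nc(SC)nc3ncccc23)cc1`, gives a number in this assay, 3770 nM. Within this small set compound 1 therefore stands at the weak end, where most of the readings sit, since the limit of > 100000 nM in this assay, at which 2 of the 3 values shown sit, and only compound 2 falls short of it.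

The step to compound 4, of structure `CCCCC[Se]c1nc(N)c2cccnc2n1`, is a single change: one nitrogen atom in place of a group of 6 heavy atoms (5 carbon, 1 selenium; no ring), on an aromatic carbon. Among the compounds with values here, no measured pair in the set carries this change, so its size is not known from the data; what remains of compound 1 is unchanged. Given that compound 1 and compound 3 both sit at the limit, while compound 2 with its differing substitution pattern is the one compound with a numerical reading, the expectation for this step is no movement beyond the scatter, and most probably a further limit. Compound 4 is estimated in this assay at 100000 nM, with a range of 20000 nM to 300000 nM. The step this implies is expected to be a number no higher from compound 1 to compound 4 (the limit leaves the size open).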

Compound 4, concentration for total growth inhibition: 44900 nM
For compound 4 the middle estimate is 2.2-fold (0.35 log units) above the measured one; the range from low to high includes it.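

In this assay, amino in place of the group of 6 heavy atoms (5 carbon, 1 selenium), on the aromatic carbon next to the ring nitrogen, gives an at least 2.2-fold lower number from compound 1 to compound 4 (0.34 log units; beyond the scatter). Within the data shown here, this is the first sign that this position responds: a single change here is enough to bring the core of compound 1 to a numerical reading, which the earlier compounds could not show, as no measured pair carried a change at this place. Compound 1 itself remains a limit and not a number, so the step is a bound and its true size stays open: the limit of > 100000 nM in this assay, at which 2 of the 4 values shown sit.

The compounds shown leave open whether the lower number comes from the amino group entering or simply from the group of 6 heavy atoms leaving; a methylamino group, a hydroxyl group or a shorter selenium-linked alkyl chain on the same carbon would help separate the two. Also open, as far as these compounds go, is what the selenium-linked chain remaining in compound 4 contributes to its reading, which a sulfur-linked chain in its place would begin to test.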